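A Stereochemical Flip in a Long-Linker Degrader Series

A few compounds are considered here, and "the series" means these few. Any claim that something is new, unique, unknown or untested is made for them only; others in the source may bear on it.

Three closely related compounds have been tested in a functional assay on A2780 cells (Homo sapiens) for inhibition, read by CCK-8 assay, with a stated time of 72 h; on this read-out lower numbers stand for stronger inhibition and higher numbers for weaker inhibition. Compound 1, `CCCn1c(=O)c(-c2ccc(C(=O)NCc3cccnc3)cc2)nc2ccc(NC(=O)CCCCCCCCCCC(=O)N[C@H](C(=O)N3C[C@H](O)C[C@H]3C(=O)N[C@@H](C)c3ccc(-c4scnc4C)cc3)C(C)(C)C)cc21`, gives 12.1 nM in this assay. Compound 2, `CCCn1c(=O)c(-c2ccc(C(=O)NCc3cccnc3)cc2)nc2ccc(NC(=O)CCCCCCCCC(=O)N[C@H](C(=O)N3C[C@H](O)C[C@H]3C(=O)N[C@@H](C)c3ccc(-c4scnc4C)cc3)C(C)(C)C)cc21`, gives 14 nM, and compound 3, `CCCn1c(=O)c(-c2ccc(C(=O)NCc3cccnc3)cc2)nc2ccc(NC(=O)CCCCCCC(=O)N[C@H](C(=O)N3C[C@H](O)C[C@H]3C(=O)N[C@@H](C)c3ccc(-c4scnc4C)cc3)C(C)(C)C)cc21`, gives 20.8 nM. Compound 1 shows the lowest number of the three, but its gap to compound 2 and its gap to compound 3 both lie within the usual scatter of repeated measurements, so the three cannot be ranked against each other on these numbers alone. Shortening the chain between the two amides, as in compound 2 and compound 3, has not moved the read-out beyond that scatter.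

Compound 4, `CCCn1c(=O)c(-c2ccc(C(=O)NCc3cccnc3)cc2)nc2ccc(NC(=O)CCCCCCCCCCC(=O)N[C@H](C(=O)N3C[C@@H](O)C[C@@H]3C(=O)N[C@@H](C)c3ccc(-c4scnc4C)cc3)C(C)(C)C)cc21`, is the next compound to be measured. Its relation to compound 1 is this: the two compounds have the same atoms and bonds and differ only in configuration as drawn: 2 of 4 stereo elements differ; a stereocentre at a saturated ring carbon is drawn R in compound 1 and S in compound 4; a stereocentre at a saturated ring carbon is drawn S in compound 1 and R in compound 4. No measured pair among compounds 1 to 3 tests a change of configuration, so the direction and size of this step are not known from the data shown. Inverting two stereocentres while keeping every atom and bond the same is nonetheless expected to weaken inhibition markedly, so the step is estimated at a 250-fold higher number from compound 1 to compound 4 (2.39 log units; beyond the scatter). Compound 4 is therefore expected to give about 3000 nM, with a plausible range from 400 nM to 20000 nM.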

Compound 4, half-maximal inhibitory concentration: 143 nM
Compound 4: the middle estimate sits 21-fold (1.32 log units) above what was measured; measured number below the stated range.
By their numbers in this assay, from the lowest: compounds 1, 2 and 3 (each within the scatter of the next); then compound 4.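

Inverting the two stereocentres at saturated ring carbons gives, in this assay, a 12-fold higher number from compound 1 to compound 4 (1.07 log units; beyond the scatter). Among the compounds shown here, this is the first step in this set that lies beyond the scatter, whereas compounds 1, 2 and 3, with their different chain lengths, all stay within the scatter of the next. The step can be assigned to configuration alone, because no atom or bond changes: the fact that compounds 1 and 4 differ only in the configuration as drawn

The inversion weakens the read-out without removing it, as compound 4 still gives 143 nM.

Both stereocentres change together, so the compounds shown cannot say how much of the step belongs to each one, or whether the same inversion would have a similar effect on the shorter chains of compound 2 and compound 3. They also leave open how a fluorine or an amine in place of the ring hydroxyl group would affect the read-out, and whether the remaining inhibition by compound 4 arises in the same way as that by compound 1.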